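Swapping fluoro for nitro on a shared core

The source may report more compounds than this note shows. Statements on the series, on what has been measured and on what is new or still open speak of the compounds shown alone.

Measured in a functional assay on NCI-H727 cells (Homo sapiens) for cytotoxicity, with a stated time of 48 h; a lower number here means a stronger inhibitor, a higher number a weaker inhibitor:
Compound 1 `COc1cc(OC)c(C(=O)/C=C/c2ccc(Cl)cc2)c(OC)c1`: 6000 nM
Compound 2 `COc1cc(OC)c(C(=O)/C=C/c2ccc(F)cc2)c(OC)c1`: 5500 nM

Compound 2 cannot be ranked against compound 1, since the two values lie within the scatter of each other. Compound 3 `COc1cc(OC)c(C(=O)/C=C/c2ccc([N+](=O)[O-])cc2)c(OC)c1` has nitro in place of fluoro on an aromatic carbon, para to a large group (nitro in place of fluoro on an aromatic carbon). For the measured compounds named here, the only measured step bearing on this place is a 1.1-fold lower number from compound 1 to compound 2 (0.04 log units; within the scatter), with fluoro in place of chloro. Going by the values given here, no measured compound carries nitro, so this is a weak guide, and no step beyond the scatter is expected in this assay, in either direction. The expected change is a 1.1-fold lower number from compound 2 to compound 3 (0.04 log units; within the scatter). For compound 3 the estimate is 5000 nM, with an expected range from 1800 nM to 14000 nM.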

Compound 3, half-maximal inhibitory concentration: 4100 nM
The estimate for compound 3 lay 1.2-fold (0.09 log units) above the measured number; low and high end bracket the measured number.
By their numbers in this assay, from the lowest: compounds 3, 2 and 1 (each within the scatter of the next).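

In this assay, the place para to a large group accepts nitro as well as the two halogens with no step beyond the scatter: there is a 1.3-fold lower number from compound 2 to compound 3 (0.13 log units; within the scatter), and a 1.5-fold lower number from compound 1 to compound 3 (0.17 log units; within the scatter). Among these three compounds, then, a larger group carrying hydrogen-bond acceptors leaves the number about where fluoro and chloro put it. Nothing available explains this flat result. From the compounds shown here alone, whether an amine or a carboxylic acid at this place would move the number beyond the scatter stays open, as does the effect of changes elsewhere on the shared core.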